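Compound 2 to compound 3: diethylamino out, hydroxy in

A few compounds are considered here, and "the series" means these few. Any claim that something is new, unique, unknown or untested is made for them only; others in the source may bear on it.

Of the compounds shown here, two have numbers so far in a functional assay on LoVo cells (Homo sapiens) for cytotoxicity, read by colorimetric assay and MTT assay; on this read-out higher numbers stand for weaker inhibition and lower numbers for stronger inhibition. Compound 1 `COc1cccc2cc(-c3ccccc3)c(O)nc12` gives 10000 nM. Compound 2 `CCN(CC)C(=O)Cn1c(=O)c(-c2ccc(OC)cc2)cc2c(OC)cc(OC)cc21` gives 10000 nM, level with compound 1 at the digits shown. Compound 3 `COc1ccc(-c2cc3c(OC)cc(OC)cc3n(CC(=O)O)c2=O)cc1` has not yet been measured. It keeps the core of compound 2 and carries a single change: hydroxy in place of diethylamino on a carbonyl carbon, so that diethylcarbamoyl becomes carboxy. Among the measured compounds shown here, no measured pair shows a change of this kind, so there is no direct precedent. For the measured compounds named here, the only guide is that compound 2 stands at 10000 nM. In this assay no step beyond the usual scatter is expected, in either direction. The estimated size of the change is no change at the digits printed from compound 2 to compound 3 (within the scatter). The estimate for compound 3 is 10000 nM, with an expected range of 4000 nM to 20000 nM.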

Compound 3, half-maximal inhibitory concentration: 10000 nM
The estimate for compound 3 equals the measured number at the digits printed; the range from low to high includes it.
By their numbers in this assay, from the lowest: compounds 1, 2 and 3 (each within the scatter of the next).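

In this assay, hydroxy in place of diethylamino on a carbonyl carbon gives no change at the digits printed from compound 2 to compound 3 (within the scatter). Among the compounds shown here, this is the first comparison that differs in one place, and it shows that diethylcarbamoyl and carboxy read alike here: removing the diethylamino group and adding a hydrogen-bond donor leaves the read-out within the scatter. No measured property of these groups bears on this result.

For the compounds shown here, with only this one step at the carbonyl carbon, it remains open whether any group there can move the read-out away from the level of compound 3 at 10000 nM. A methyl ester, a morpholine amide or a longer chain ending in a carboxylic acid would test this, and a primary amine on the chain would add a basic-free comparison of a different kind.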